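This account rests on a few compounds, and the source may have more. Where it says the series, first, only, none or still open, it means among the compounds named here.

Compound 1 `CN(C)Cc1ccc2nc(NC(=O)N/N=C/c3cn(Cc4ccccc4Cl)c4ccccc34)sc2c1` is the starting point. Going by the values given here, in a functional assay on NCI-H460 cells (Homo sapiens) for cytotoxicity, read by MTT assay, with a stated time of 72 h (on this read-out higher numbers stand for weaker inhibition and lower numbers for stronger inhibition), compound 1 gives 1600 nM, the highest number of the three measured so far, which makes it the weakest inhibitor among them. Compound 2 `CN(C)Cc1ccc2nc(NC(=O)N/N=C/c3cn(Cc4ccc(Cl)cc4)c4ccccc34)sc2c1`, with 4-chlorophenyl in place of 2-chlorophenyl, gives 290 nM, and compound 3 `CN(C)Cc1ccc2nc(NC(=O)N/N=C/c3cn(Cc4cccc(Cl)c4)c4ccccc34)sc2c1`, with 3-chlorophenyl in that place, gives 420 nM. These changes amount to a 5.5-fold lower number from compound 1 to compound 2 (0.74 log units; beyond the scatter) and a 3.8-fold lower number from compound 1 to compound 3 (0.58 log units; beyond the scatter), whereas the remaining comparison is a 1.4-fold higher number from compound 2 to compound 3 (0.16 log units; within the scatter).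

Compound 4 `CCN(CC)Cc1ccc2nc(NC(=O)N/N=C/c3cn(Cc4ccccc4Cl)c4ccccc34)sc2c1` keeps the 2-chlorophenyl of compound 1 and differs elsewhere: diethylamino in place of dimethylamino on a saturated chain carbon bound to an aromatic carbon. In words, it has diethylamino in place of dimethylamino on a saturated chain carbon bound to an aromatic carbon. Among the compounds with values here, no measured step involves this group, so the data offer no direct guide and favour no direction. The chlorophenyl steps bear on it only indirectly, showing how far one small change has moved the number in this series. The larger of them, a 5.5-fold lower number from compound 1 to compound 2 (0.74 log units; beyond the scatter), serves as a rough outer bound, and a shift of that size is not expected here. The expected step is a 1.1-fold lower number from compound 1 to compound 4 (0.03 log units; within the scatter), which would be none beyond the scatter. In this assay, compound 4 is estimated at 1500 nM, with an expected range from 600 nM to 3800 nM.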

Compound 4, half-maximal inhibitory concentration: 980 nM
Compound 4: the middle estimate sits 1.5-fold (0.18 log units) above what was measured, within the range that was stated.
By their numbers in this assay, from the lowest: compounds 2 and 3 (each within the scatter of the next); then compounds 4 and 1 (each within the scatter of the next).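

Putting diethylamino in place of dimethylamino on a saturated chain carbon bound to an aromatic carbon gives, in this assay, a 1.6-fold lower number from compound 1 to compound 4 (0.21 log units; within the scatter), so the data do not separate these two compounds even though the entering group has 5 heavy atoms and the leaving group 3. Going by these compounds alone, this is the first measured look at this place, and it shows that this particular enlargement of the amine leaves the number within the scatter, unlike moving the chlorine on the benzyl side, which gave a 5.5-fold lower number from compound 1 to compound 2 (0.74 log units; beyond the scatter) and a 3.8-fold lower number from compound 1 to compound 3 (0.58 log units; beyond the scatter). No measurement is available to explain why the number holds at this place.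

As far as these compounds go, the diethylamino group appears here only with the 2-chlorophenyl of compound 1, so whether it would behave the same way alongside the 4-chlorophenyl of compound 2 or the 3-chlorophenyl of compound 3 remains open. From the compounds shown here alone, it is also open how far this place tolerates change, since a ring amine such as morpholine or piperidine, a longer chain between the amine and the core, or a carboxylic acid in place of the amine could each give a different result.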